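The compounds below may be only part of what the source reports. "The series", "measured", "known", "first", "only" and "open" are said of these compounds alone.

Series notes, halogen swap on two cores.

Compound 1 `O=C1/C(=C/c2cccc(Cl)c2)Cc2ccccc21` and compound 2 `O=C1/C(=C/c2cccc(Br)c2)Cc2ccccc21` share one core; compound 3 `O=C1CCCCC/C1=C\c1cccc(Cl)c1` and compound 4 `O=C1CCCCC/C1=C\c1cccc(Br)c1` share another. How the two cores differ is not broken down here. Within the first pair the change is bromo in place of chloro on an aromatic carbon In a functional assay on L1210 cells (Mus musculus) for inhibition (a higher number here means a weaker inhibitor, a lower number a stronger inhibitor), compound 1 gives 41200 nM and compound 2 gives 43300 nM, so the step is a 1.1-fold higher number from compound 1 to compound 2 (0.02 log units; within the scatter), a result that cannot be told apart from repetition of the same measurement.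

Compound 3, on the second core, is the weakest inhibitor of the three measured in this assay, giving 144000 nM. Compound 4 differs from compound 3 in the same way: bromo in place of chloro on an aromatic carbon The surroundings are described differently in the two pairs, meta to a large group in the first and meta to a group of 9 heavy atoms in the second, so this is the same kind of change rather than the same change.

With one instance of the swap giving a step within the scatter, the expectation for this assay is that compound 4 lands close to compound 3, with the expected step being a 1.0-fold higher number from compound 3 to compound 4 (0.02 log units; within the scatter). For the measured compounds named here, this rests on the single step of a 1.1-fold higher number from compound 1 to compound 2 (0.02 log units; within the scatter) and on nothing else, so the range is kept wide. The estimated value for compound 4 in this assay is 150000 nM, expected to fall between 80000 nM and 280000 nM.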

Compound 4, half-maximal inhibitory concentration: 246000 nM
Compound 4: middle estimate off by 1.6-fold (0.21 log units), on the low side, within the range that was stated.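

In this assay the second instance of the swap gives a 1.7-fold higher number from compound 3 to compound 4 (0.23 log units; within the scatter), so bromo in place of chloro on an aromatic carbon stays within the scatter on this core as well. Set side by side, the two instances cannot be told apart, and the change carries from the core of compound 1 to the core of compound 3 without a readable difference: the same change on two cores in this assay, a 1.1-fold higher number (0.02 log units; within the scatter) from compound 1 to compound 2 and a 1.7-fold higher number (0.23 log units; within the scatter) from compound 3 to compound 4, 1.6-fold (0.21 log units) apart, within the scatter of two such steps. This shows only that the two halogens are interchangeable on these two cores in this one assay; with just two pairs of compounds, it does not show that the same holds on any further core, and it gives no reason why the steps stay small.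

Still open, going by these compounds, is whether anything other than these two halogens at this place on the aromatic ring would shift the number beyond the scatter, for example a fluoro, a methoxy group, an amine or a carboxylic acid in place of the chloro or bromo. Also open, on these data alone, is whether the swap would remain as small on a core carrying a further substituent, such as a longer chain.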